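This account rests on a few compounds, and the source may have more. Where it says the series, first, only, none or still open, it means among the compounds named here.

The three measured compounds share one core and differ in the group on its carbonyl carbon. In a functional assay on PC-3 cells (Homo sapiens) for inhibition, read by sulforhodamine B assay, with a stated time of 72 h (a higher number here means a weaker inhibitor, a lower number a stronger inhibitor), compound 1 `Nc1sc(-c2ccc(Cl)cc2)c(-c2ccc(Cl)cc2)c1C(=O)N1CCCCC1=O` gives 4940 nM and compound 2 `Nc1sc(-c2ccc(Cl)cc2)c(-c2ccc(Cl)cc2)c1C(=O)N1CCCC1` gives 6220 nM while compound 3 `Nc1sc(-c2ccc(Cl)cc2)c(-c2ccc(Cl)cc2)c1C(=O)NC1CC1` gives 3680 nM as its value. These numbers all lie within the scatter of one another, so compound 3 stands level with the other two. The step followed here leads from compound 3 to compound 4 `Nc1sc(-c2ccc(Cl)cc2)c(-c2ccc(Cl)cc2)c1C(=O)NC1CCCC1` with cyclopentyl in place of cyclopropyl on an amide-type nitrogen is the whole difference. Among the measured compounds shown here, two measured steps bear on this by changing the group on the carbonyl carbon: a 1.7-fold lower number from compound 2 to compound 3 (0.23 log units; within the scatter) and a 1.3-fold lower number from compound 1 to compound 3 (0.13 log units; within the scatter) both stay within the scatter. For the measured compounds named here, none of the measured steps swaps one carbon ring for another on the amide-type nitrogen, so they are only a loose guide. With those small steps as the guide, no shift beyond the scatter is expected in this assay in either direction. The expected step is a 1.1-fold higher number from compound 3 to compound 4 (0.04 log units; within the scatter) and that stays within the scatter. For compound 4 the expected value is 4000 nM with 1800 nM to 9000 nM as the likely range.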

Compound 4, half-maximal inhibitory concentration: 21200 nM
For compound 4 the middle estimate is 5.3-fold (0.72 log units) below the measured one; measured number outside the range, above it.
By their numbers in this assay, from the lowest: compounds 3, 1 and 2 (each within the scatter of the next); then compound 4.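

In this assay, among the compounds shown here, the amide-type nitrogen proves sensitive to which carbon ring it carries: cyclopentyl in place of cyclopropyl gives a 5.8-fold higher number from compound 3 to compound 4 (0.76 log units; beyond the scatter) and is a step beyond the scatter, unlike any step among the earlier compounds. The two other comparisons point the same way, with a 3.4-fold higher number from compound 2 to compound 4 (0.53 log units; beyond the scatter) and a 4.3-fold higher number from compound 1 to compound 4 (0.63 log units; beyond the scatter), so compound 4 stands apart as a weaker inhibitor than the three earlier compounds, which remain level with one another. Nothing available explains this loss.

Still open, going by these compounds, is how the number would run through a cyclobutyl or cyclohexyl ring on the same nitrogen. Also open, on these data alone, is whether an open-chain group such as isopropyl, or a cyclopentyl ring carrying an amine, would sit with compound 3 or with compound 4.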